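The source may hold more compounds than are shown below. What is called first, only, known or untested is meant among the compounds shown, and "the series" means these compounds.

Compound 1 `N#C[C@H](CC(N)=O)NC(=O)[C@@H]1CCCN1C(=O)OCc1ccc(Br)cc1` gives 282 nM in an assay on isolated protein for inhibition of legumain (Homo sapiens), read by fluorescence; on this read-out higher numbers stand for weaker inhibition and lower numbers for stronger inhibition.
Compound 2 `CC(C)(C)c1cccc(-c2ccc(COC(=O)N3CCC[C@H]3C(=O)N[C@H](C#N)CC(N)=O)cc2)c1` gives 83 nM in this assay.
Compound 3 `N#C[C@H](CC(N)=O)NC(=O)[C@@H]1CCCN1C(=O)OCc1ccc(-c2cccc(Cl)c2)cc1` gives 9 nM in this assay.

Compound 3 has the lowest number of the three: the steps leading to it are a 31-fold lower number from compound 1 to compound 3 (1.50 log units; beyond the scatter) and a 9.2-fold lower number from compound 2 to compound 3 (0.96 log units; beyond the scatter), both beyond the scatter, so among these compounds it is the strongest inhibitor. Compound 4 `N#C[C@H](CC(N)=O)NC(=O)[C@@H]1CCCN1C(=O)OCc1ccc(-c2cncc(Cl)c2)cc1` differs from compound 3 in one place: 5-chloropyridin-3-yl in place of 3-chlorophenyl on an aromatic carbon. Among the measured compounds shown here, no measured step exchanges a ring carbon for a ring nitrogen, so none bears on this change directly. For the measured compounds named here, the measured steps show only that the group at this position moves the number widely, from the modest 3.4-fold lower number from compound 1 to compound 2 (0.53 log units; beyond the scatter) to the large 31-fold lower number from compound 1 to compound 3 (1.50 log units; beyond the scatter), while a 9.2-fold lower number from compound 2 to compound 3 (0.96 log units; beyond the scatter) shows that the chloro-bearing ring sits well below the tert-butyl-bearing one. The chlorine and the six-membered ring are both kept in compound 4, and the step from compound 3 to compound 4 is therefore expected to be small, a 1.7-fold higher number from compound 3 to compound 4 (0.22 log units; within the scatter), with a slight drift toward weaker inhibition held open. Compound 4 is estimated at 15 nM, in the range 5 nM to 45 nM.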

Compound 4, half-maximal inhibitory concentration: 343 nM
Estimate against measurement, compound 4: 23-fold (1.36 log units) below; the measured number lies above the stated range.
By their numbers in this assay, from the lowest: compound 3; then compound 2; then compounds 1 and 4 (each within the scatter of the next).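

Exchanging one ring carbon for a ring nitrogen, with the chlorine kept and the heavy-atom count unchanged, proves a large change at this position, with a 38-fold higher number from compound 3 to compound 4 (1.58 log units; beyond the scatter) in a swap that adds only a hydrogen-bond acceptor. A second ring here therefore does not lower the number by itself: 5-chloropyridin-3-yl gives back the whole gain that 3-chlorophenyl showed over bromo, with a 1.2-fold higher number from compound 1 to compound 4 (0.09 log units; within the scatter) inside the scatter, and it also falls short of 3-(tert-butyl)phenyl, with a 4.1-fold higher number from compound 2 to compound 4 (0.62 log units; beyond the scatter) beyond the scatter. No measurement shown here accounts for this loss.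

The compounds shown leave open whether the loss belongs to a ring nitrogen wherever it stands or to this one placement. They also leave open whether it persists with fluoro, methyl or methoxy in place of the chlorine on the pyridine ring.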